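The source may report more compounds than this note shows. Statements on the series, on what has been measured and on what is new or still open speak of the compounds shown alone.

Measured in a functional assay on HT-29 cells (Homo sapiens) for antiproliferative activity, read by MTT assay, with a stated time of 24 h; a lower number here means a stronger inhibitor, a higher number a weaker inhibitor:
- Compound 1 `COc1ccc(C(=O)/C=C/c2ccc(Cl)cc2)c2c1C=CC(C)(C)O2`: > 10000 nM
- Compound 2 `COc1ccc(C(=O)/C=C/c2cccc(O)c2)c2c1C=CC(C)(C)O2`: > 10000 nM

Compound 2 stands at > 10000 nM, which is a limit and not a number. Compound 1 also gives only a limit, > 10000 nM. The record in this assay therefore amounts to the limit of > 10000 nM in this assay, at which 2 of the 2 values shown sit.

Compound 3 `COc1ccc(C(=O)/C=C/c2cc(Cl)ccc2O)c2c1C=CC(C)(C)O2` differs from compound 2 on a double-bonded chain carbon bound to a double-bonded chain carbon: 5-chloro-2-hydroxyphenyl in place of 3-hydroxyphenyl on a double-bonded chain carbon bound to a double-bonded chain carbon. It carries 5-chloro-2-hydroxyphenyl in place of 3-hydroxyphenyl.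

For the measured compounds named here, the one measured step that bears on this change is a step that the two limits leave unreadable from compound 1 to compound 2, so it offers no size to carry over and no direction. No change beyond the usual scatter is expected, and the estimated step is a step that the limit leaves unreadable from compound 2 to compound 3. For compound 3 the expected value is 12000 nM, with an estimated range from 5000 nM to 30000 nM.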

Compound 3, half-maximal inhibitory concentration: 4970 nM
For compound 3 the middle estimate is 2.4-fold (0.38 log units) above the measured one, outside the stated range (below it).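

In this assay, compound 3 gives 4970 nM, the first number rather than a limit at this place on a double-bonded chain carbon bound to a double-bonded chain carbon. From the compounds shown here alone, the change to 5-chloro-2-hydroxyphenyl gives an at least 2.0-fold lower number from compound 2 to compound 3 (0.30 log units; that floor lies within the scatter), and the change from 4-chlorophenyl gives an at least 2.0-fold lower number from compound 1 to compound 3 (0.30 log units; that floor lies within the scatter); both are floors only, so the true size of each step stays open. Only the ring carrying both chlorine and hydroxyl gives a number, while the two rings carrying one of these stay at a limit: the limit of > 10000 nM in this assay, at which 2 of the 3 values shown sit.

The compounds shown leave open whether the chlorine, the place of the hydroxyl or the two together account for the number. They also leave open how an amine or a carboxylic acid on this ring would read in this assay.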